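Working notes: sec-butyl for anilino on the double-bonded nitrogen

A few compounds are considered here, and "the series" means these few. Any claim that something is new, unique, unknown or untested is made for them only; others in the source may bear on it.

Among the measured compounds shown here, compound 3 `C/C(=N\Nc1ccccc1)c1c(O)c2ccccc2oc1=O` is the one member of the series with an actual number in an assay on isolated protein for inhibition of myosin-2 (Bos taurus), read by spectrophotometry, with a stated time of 24 min; on this read-out lower numbers stand for stronger inhibition and higher numbers for weaker inhibition: compound 3 gives 27000 nM. Compound 1 `C/C(=N\Cc1ccccc1)c1c(O)c2ccccc2[nH]c1=O` reaches only a limit of the assay, >= 100000 nM, in this assay. Compound 2 `C/C(=N\C(C)C)c1c(O)c2ccccc2[nH]c1=O` likewise stops at the limit >= 100000 nM. For the measured compounds named here, the step that the two limits leave unreadable from compound 1 to compound 2 thus cannot be sized, as the limit of >= 100000 nM in this assay, at which 2 of the 3 values shown sit, records, and it is the only measured change on the double-bonded nitrogen. Compound 4 `CCC(C)/N=C(\C)c1c(O)c2ccccc2oc1=O` differs from compound 3 by sec-butyl in place of anilino on a double-bonded nitrogen. On these data alone, with no readable step bearing on this swap, the direction in this assay stays open; the expectation leans toward a somewhat weaker number. Compound 4 is expected to give 60000 nM, within 15000 nM to 150000 nM, an estimated step of a 2.2-fold higher number from compound 3 to compound 4 (0.35 log units; beyond the scatter).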

Compound 4, half-maximal inhibitory concentration: >= 100000 nM
Compound 4 gave a limit, no number (the forecaster's own chance of this, stated with the estimate: 40%); middle value at least 1.6-fold (0.22 log units) away from the limit.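

Among the compounds shown here, on a double-bonded nitrogen, sec-butyl in place of anilino gives the first readable step at this position in this assay: an at least 3.7-fold higher number from compound 3 to compound 4 (0.56 log units; beyond the scatter). With the anilino group gone, no compound shown retains a number, and compound 4 stops at a limit of the assay: the limit of >= 100000 nM in this assay, at which 3 of the 4 values shown sit.

On these data alone, the full size of this step stays unknown, and the step from compound 1 to compound 2 cannot be read. As far as these compounds go, whether the anilino ring or its nitrogen carries the difference stays open; cyclohexylamino or methylamino on the same nitrogen would bear on that.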